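This account rests on a few compounds, and the source may have more. Where it says the series, first, only, none or still open, it means among the compounds named here.

Measured in a functional assay on MCF7 cells (Homo sapiens) for inhibition, read by MTT assay, with a stated time of 72 h; on this read-out lower numbers stand for stronger inhibition and higher numbers for weaker inhibition:
- Compound 1 `Cc1ccc(NC(=O)C2CCN(C/C=C/c3ccccc3)CC2)cc1`: 30000 nM
- Compound 2 `CCc1ccc(NC(=O)C2CCN(C/C=C/c3ccccc3)CC2)cc1`: 20000 nM
- Compound 3 `COc1ccccc1NC(=O)C1CCN(C/C=C/c2ccccc2)CC1`: > 100000 nM

The last of these entries is a limit of the assay and not a number. Going by the values given here, it is the only value of the three that stands as a limit, so compound 3 has no exact position in this assay. Compound 4 `O=C(Nc1ccc(F)c(Br)c1)C1CCN(C/C=C/c2ccccc2)CC1` differs from compound 3 on the amide-type nitrogen, with 3-bromo-4-fluorophenyl in place of 2-methoxyphenyl (3-bromo-4-fluorophenyl in place of 2-methoxyphenyl on an amide-type nitrogen).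

Among the compounds with values here, no measured compound carries this new group. The nearest evidence comes from the two changes at the same nitrogen, an at least 3.3-fold higher number from compound 1 to compound 3 (0.52 log units; beyond the scatter) and an at least 5.0-fold higher number from compound 2 to compound 3 (0.69 log units; beyond the scatter). Read backwards, they suggest that removing the 2-methoxyphenyl may lower the number by a modest amount or more. The step of a 1.5-fold lower number from compound 1 to compound 2 (0.18 log units; within the scatter) adds little.

The expected step is an at least 4.0-fold lower number from compound 3 to compound 4 (0.60 log units; beyond the scatter), toward a lower number, though its size is uncertain. For compound 4 the estimate is 25000 nM, with an expected range from 8000 nM to 90000 nM.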

Compound 4, half-maximal inhibitory concentration: 13500 nM
For compound 4 the middle estimate is 1.9-fold (0.27 log units) above the measured one, within the range that was stated.
By their numbers in this assay, from the lowest: compounds 4, 2 and 1 (each within the scatter of the next, the first and the last beyond it). At a limit, above all of these: compound 3.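

In this assay, compound 4 shows that the poor result of compound 3 does not extend to every other aryl group on this amide-type nitrogen: 3-bromo-4-fluorophenyl in place of 2-methoxyphenyl gives an at least 7.4-fold lower number from compound 3 to compound 4 (0.86 log units; beyond the scatter). On these data alone, compound 3 stands at a limit of the assay and not a number, and the true size of this step stays unknown: the limit of > 100000 nM in this assay, at which 1 of the 4 values shown sits. Set against 4-ethylphenyl, the new group gives a 1.5-fold lower number from compound 2 to compound 4 (0.17 log units; within the scatter), and set against 4-methylphenyl it gives a 2.2-fold lower number from compound 1 to compound 4 (0.35 log units; beyond the scatter), so a ring bearing bromine and fluorine serves at this nitrogen at least as well as these alkyl-bearing rings.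

As far as these compounds go, it remains open whether bromine or fluorine alone would do as much. From the compounds shown here alone, it is also open whether a nitrile or a carboxylic acid on this ring would hold the level of compound 4.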